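The source may report more compounds than this note shows. Statements on the series, on what has been measured and on what is new or still open speak of the compounds shown alone.

Measured in a functional assay on THP-1 cells (Homo sapiens) for inhibition, read by sulforhodamine B assay, with a stated time of 48 h, tested at 50 uM; a lower number here means less inhibition of growth, a higher number more inhibition of growth at the concentration tested:
- compound 1 `COc1cc(/C=C/C(=O)/C=C/c2cccc3ccccc23)ccc1OCc1cn(CCCOc2cc(=O)oc3ccccc23)nn1`: 71%
- compound 2 `COc1cccc(/C=C/C(=O)/C=C/c2ccc(OCc3cn(CCCCOc4cc(=O)oc5ccccc45)nn3)c(OC)c2)c1`: 47%
- compound 3 `COc1cc(/C=C/C(=O)/C=C/c2cccc3ccccc23)ccc1OCc1cn(CCCCOc2cc(=O)oc3ccccc23)nn1`: 54%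

Compound 3 lies within the scatter of compound 2, while compound 1 stands beyond the scatter above it. Next is compound 4 `COc1cc(/C=C/C(=O)/C=C/c2cc(OC)c(OC)c(OC)c2)ccc1OCc1cn(CCCCOc2cc(=O)oc3ccccc23)nn1`, with this change from compound 3: 3,4,5-trimethoxyphenyl in place of naphthalen-1-yl on a double-bonded chain carbon bound to a double-bonded chain carbon. Within the data shown here, one measured step bears on this place: naphthalen-1-yl in place of 3-methoxyphenyl gave a number 7 percentage points higher from compound 2 to compound 3 (within the scatter). That single step is small, so no shift beyond the scatter is expected in this assay. The expected step is a number 4 percentage points lower from compound 3 to compound 4 (within the scatter). For compound 4 the estimate is 50%, with an expected range of 35% to 65%.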

Compound 4, percent growth inhibition at one concentration: 65%
The estimate for compound 4 lay 15 percentage points below the measured number; low and high end bracket the measured number.
By their numbers in this assay, from the lowest: compounds 2 and 3 (each within the scatter of the next); then compounds 4 and 1 (each within the scatter of the next).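

At this place, on a double-bonded chain carbon bound to a double-bonded chain carbon, the choice of group now moves growth inhibition in this assay beyond the scatter: 3,4,5-trimethoxyphenyl in place of naphthalen-1-yl gives a number 11 percentage points higher from compound 3 to compound 4 (beyond the scatter), and in place of 3-methoxyphenyl it gives a number 18 percentage points higher from compound 2 to compound 4 (beyond the scatter). The earlier step between those two replaced groups stayed within the scatter, so only 3,4,5-trimethoxyphenyl separates from them here. Nothing measured explains this gain.

Open, going by these compounds, is whether a 4-dimethylaminophenyl or 4-carboxyphenyl group at this place would retain the gain. Also open, on these data alone, is whether 3,4,5-trimethoxyphenyl gives a similar step on the chain of compound 1.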